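The source may report more compounds than this note shows. Statements on the series, on what has been measured and on what is new or still open speak of the compounds shown alone.

Compound 3 `Nc1ncnc2c1ncn2CC(O)C(=O)OC1CCCCC1` gives 100 ug/mL in a functional assay on Vero cells (Chlorocebus sabaeus) for cytotoxicity (on this read-out lower numbers stand for higher toxicity in this test and higher numbers for lower toxicity in this test), and its nearest neighbour among the measured esters, compound 1 `CCCCCCCCOC(=O)C(O)Cn1cnc2c(N)ncnc21`, gives 200 ug/mL in this assay, a gap that stays within the scatter. Compound 2 `COC(=O)C(O)Cn1cnc2c(N)ncnc21` gives only a limit in this assay, namely > 400 ug/mL. The next compound is compound 4 `CCCOC(=O)C(O)Cn1cnc2c(N)ncnc21`, and its difference from compound 3 lies on the oxygen next to the carbonyl group: propyl in place of cyclohexyl on an oxygen next to a carbonyl group.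

Among the measured compounds shown here, two measured steps bear on this change. Exchanging methyl for cyclohexyl gave an at least 4.0-fold lower number from compound 2 to compound 3 (0.60 log units; beyond the scatter), exchanging octyl for cyclohexyl gave a 2.0-fold lower number from compound 1 to compound 3 (0.30 log units; within the scatter), and the exchange of octyl for methyl gave an at least 2.0-fold higher number from compound 1 to compound 2 (0.30 log units; that floor lies within the scatter). Propyl is longer than methyl and shorter than octyl, so the move away from cyclohexyl is expected to raise the number, in the direction seen for compound 2 though not necessarily as far as its limit. Compound 4 is therefore expected to give 300 ug/mL in this assay, between 150 ug/mL and 800 ug/mL. That estimate means an expected step of a 3.0-fold higher number from compound 3 to compound 4 (0.48 log units; beyond the scatter).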

Compound 4, minimum cytotoxic concentration: > 400 ug/mL
Compound 4: only a limit was reported; the forecaster's own chance of this, stated with the estimate: 30%; at least 1.3-fold (0.12 log units) between middle value and limit.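

In this assay, the exchange of cyclohexyl for propyl on an oxygen next to a carbonyl group gives an at least 4.0-fold higher number from compound 3 to compound 4 (0.60 log units; beyond the scatter), so compound 4 is a second ester, after compound 2, that stands apart from compound 3 beyond the scatter. The comparison with the octyl ester gives an at least 2.0-fold higher number from compound 1 to compound 4 (0.30 log units; that floor lies within the scatter); that floor lies within the scatter, so the data do not firmly separate compound 4 from compound 1, just as they did not separate compound 2 from it. The step between compound 2 and compound 4 cannot be read, since each of the two carries only a limit, and the new result adds a second compound to that limit: the limit of > 400 ug/mL in this assay, at which 2 of the 4 values shown sit.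

As far as these compounds go, how far the true values of the methyl and propyl esters lie beyond that limit stays open, and so does any order between them or any steady trend with chain length from propyl up to octyl. From the compounds shown here alone, it is also open where an isopropyl or butyl ester would fall, and whether a carboxylic acid in place of the ester would stay at the limit.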